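A few compounds are considered here, and "the series" means these few. Any claim that something is new, unique, unknown or untested is made for them only; others in the source may bear on it.

Measured in an in vitro ADME assay on microsomes from liver (Homo sapiens) for metabolic stability, tested at 1 uM; on this read-out lower numbers stand for a shorter-lived compound and higher numbers for a longer-lived compound:
- Compound 1 `CS(=O)(=O)Nc1ccc2c(c1)S(=O)(=O)N=C(C1=C(O)[C@@H]3[C@H]4CC[C@H](C4)[C@@H]3N(Cc3ccccc3)C1=O)N2`: > 1 h (a limit)
- Compound 2 `CS(=O)(=O)Nc1ccc2c(c1)S(=O)(=O)N=C(C1=C(O)[C@@H]3[C@H]4CC[C@H](C4)[C@@H]3N(Cc3ccccc3F)C1=O)N2`: > 1 h (a limit)
- Compound 3 `CS(=O)(=O)Nc1ccc2c(c1)S(=O)(=O)N=C(C1=C(O)[C@@H]3[C@H]4CC[C@H](C4)[C@@H]3N(Cc3ccccc3Cl)C1=O)N2`: > 1 h (a limit)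

Compound 3 has no number, and its place is the limit of > 1 h in this assay, at which 3 of the 3 values shown sit. Compound 4 `CS(=O)(=O)Nc1ccc2c(c1)S(=O)(=O)N=C(C1=C(O)[C@@H]3[C@H]4CC[C@H](C4)[C@@H]3N(Cc3ccc(F)c(Cl)c3)C1=O)N2` differs from compound 3 as follows: 3-chloro-4-fluorophenyl in place of 2-chlorophenyl on a saturated chain carbon bound to an amide-type nitrogen in a ring. The change lies on a saturated chain carbon bound to an amide-type nitrogen in a ring. The steps bearing on it are a step that the two limits leave unreadable from compound 1 to compound 3, a step that the two limits leave unreadable from compound 2 to compound 3 and a step that the two limits leave unreadable from compound 1 to compound 2, and none of them gives a size. No step beyond the scatter is therefore expected in this assay, and no direction is expected either. The expected step is a step that the limit leaves unreadable from compound 3 to compound 4. For compound 4 the estimated half-life is 1.5 h, with an expected range from 0.7 h to 4 h.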

Compound 4, half-life: > 1 h
Compound 4: a limit, no number; the forecaster's own chance of this, stated with the estimate: 75%; the middle value does not contradict the limit.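

In this assay, going by these compounds alone, compound 4 gives > 1 h, a limit, so no step from compound 1, compound 2 or compound 3 to compound 4 can be read. From the compounds shown here alone, how long each half-life actually is, and whether these changes alter it, stays open.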